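The compounds below may be only part of what the source reports. "The series", "measured", "known", "first", "only" and "open" are said of these compounds alone.

Working notes on the shared core of compound 1 `Cc1ccc(NC2=CC(=O)c3c(nc4n3[C@H]3OC[C@@H](O)[C@H]3OC4)C2=O)cc1C` and the amine group on it. In a functional assay on ECa-109 cells for inhibition, with ECa-109 cell line (Homo sapiens) as the target, read by sulforhodamine B assay (on this read-out lower numbers stand for stronger inhibition and higher numbers for weaker inhibition), compound 1 gives 4090 nM. Compound 2 `Cc1ccc(NC2=CC(=O)c3c(nc4n3[C@H]3OC[C@@H](O)[C@H]3OC4)C2=O)cc1` reaches only a limit in this assay, compound 2 giving > 4000 nM. Compound 3 `O=C1C(NC2CCCCC2)=CC(=O)c2c1nc1n2[C@H]2OC[C@@H](O)[C@H]2OC1` also stands at a limit in this assay, compound 3 giving > 16000 nM. Compound 3 therefore holds no plain number; of the three values shown it is the one at the limit of > 16000 nM in this assay, at which 1 of the 3 values shown sits, while another sits at the limit of > 4000 nM in this assay, at which 1 of the 3 values shown sits. The steps among the measured compounds read a step that the limit leaves unreadable from compound 1 to compound 2, an at least 3.9-fold higher number from compound 1 to compound 3 (0.59 log units; beyond the scatter) and a step that the two limits leave unreadable from compound 2 to compound 3. For the measured compounds named here, only the step from compound 1 to compound 3 is readable, and it is the one that bears here, as it already exchanges an aromatic amine for cyclohexylamino.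

Compound 4 `CCCN(CCC)C1=CC(=O)c2c(nc3n2[C@H]2OC[C@@H](O)[C@H]2OC3)C1=O` differs from compound 3 by dipropylamino in place of cyclohexylamino on a double-bonded ring carbon. No measured step trades the six-membered ring of the amine for open chains, so the direction of this change is not fixed by anything shown; the one readable step points toward weaker inhibition, and compound 3 is already at a limit. The expected step is thus a step that the limit leaves unreadable from compound 3 to compound 4, most likely again ending at a limit. Compound 4 is estimated at 20000 nM, with a range from 8000 nM to 60000 nM.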

Compound 4, half-maximal inhibitory concentration: > 16000 nM
Compound 4 ended at the assay's limit; the forecaster's own chance of this, stated with the estimate: 70%; the middle value does not contradict the limit.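

In this assay, compound 4 stands at a limit, the same one as compound 3: the limit of > 16000 nM in this assay, at which 2 of the 4 values shown sit.

For the compounds shown here, the one readable new step is an at least 3.9-fold higher number from compound 1 to compound 4 (0.59 log units; beyond the scatter), so dipropylamino, which has no ring and no hydrogen-bond donor, now joins cyclohexylamino on the weaker side of the (3,4-dimethylphenyl)amino group of compound 1. Neither the six-membered ring of cyclohexylamino nor its hydrogen-bond donor is therefore enough on its own to separate compound 3 from compound 4 at this double-bonded ring carbon, and all the remaining steps among these limits cannot be read.

As far as these compounds go, how far compound 3 and compound 4 lie past their shared limit stays open, as does whether any amine without an aromatic ring gives a plain number in this assay. A morpholine or a dimethylamino group at this carbon would show whether such amines can be ordered at all, and a benzylamino group would show whether an aromatic ring still counts once a methylene separates it from the amine nitrogen.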